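A few compounds are considered here, and "the series" means these few. Any claim that something is new, unique, unknown or untested is made for them only; others in the source may bear on it.

Measured in an ADME assay on MT4 cells (Homo sapiens) for cytotoxicity, read by MTT assay, with a stated time of 4 days; on this read-out higher numbers stand for lower toxicity in this test and lower numbers for higher toxicity in this test:
- Compound 1 `CCCNc1nc(C(C)c2c(F)cccc2F)c(C)c(=O)[nH]1`: 35000 nM
- Compound 2 `Cc1c(Cc2c(F)cccc2N2CCCC2)nc(N2CCCC2)[nH]c1=O`: > 70000 nM
- Compound 3 `Cc1c(Cc2c(F)cccc2F)nc(N2CCN(C)CC2)[nH]c1=O`: > 75000 nM

For the measured compounds named here, compound 1 holds the only actual number of the three. For compound 2, > 70000 nM is a limit of the assay and not a number. For compound 3, > 75000 nM is likewise a limit.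

Compound 4 `Cc1c(C(C)c2c(F)cccc2F)nc(N2CCCCC2)[nH]c1=O` keeps the core of compound 1 but has piperidin-1-yl in place of propylamino on an aromatic carbon. Going by the values given here, no measured pair shows this swap, so no change beyond the usual scatter is expected in this assay. Compound 4 is estimated at 40000 nM, with an expected range of 15000 nM to 90000 nM. The estimated 1.1-fold higher number from compound 1 to compound 4 (0.06 log units; within the scatter) is small.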

Compound 4, half-maximal cytotoxic concentration: > 75000 nM
Compound 4: a limit, no number (the forecaster's own chance of this, stated with the estimate: 35%); middle value at least 1.8-fold (0.27 log units) away from the limit.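

In this assay, piperidin-1-yl in place of propylamino on this aromatic carbon gives an at least 2.1-fold higher number from compound 1 to compound 4 (0.33 log units; beyond the scatter), the first comparison among these compounds that differ in this one place. For compound 4, > 75000 nM is a limit of the assay and not a number, so the step sets only a minimum size: the limit of > 75000 nM in this assay, at which 2 of the 4 values shown sit. The entering group has a ring and no hydrogen-bond donor, and this single step cannot separate those two differences. As far as these compounds go, how an open-chain tertiary amine such as dimethylamino or a longer chain such as pentylamino would read at this position remains open. So does the actual value of compound 4.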